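Hydroxy for methyl on the chain of compound 3

The source may report more compounds than this note shows. Statements on the series, on what has been measured and on what is new or still open speak of the compounds shown alone.

Compound 1, `COc1ccc(/C=N/N(Cc2ccccc2)Cc2ccccc2)cc1`, gives 220 nM in an assay on liver (Sus scrofa) for inhibition of glucose-6-phosphatase catalytic subunit 1 (Homo sapiens), using microsomes; on this read-out higher numbers stand for weaker inhibition and lower numbers for stronger inhibition.
Compound 2, `C(=N/N(Cc1ccccc1)Cc1ccccc1)\c1cccnc1`, gives 3700 nM in this assay.
Compound 3, `CCc1ccc(/C=N/N(Cc2ccccc2)Cc2ccccc2)o1`, gives 330 nM in this assay.

Compound 3 stands second highest of the three numbers. Its nearest neighbour is compound 1: a 1.5-fold higher number from compound 1 to compound 3 (0.18 log units; within the scatter). Its furthest is compound 2: an 11-fold lower number from compound 2 to compound 3 (1.05 log units; beyond the scatter). The only large movements seen, a 17-fold higher number from compound 1 to compound 2 (1.23 log units; beyond the scatter) and an 11-fold lower number from compound 2 to compound 3 (1.05 log units; beyond the scatter), both involve the exchange of pyridin-3-yl for another group on the carbon with a double bond to nitrogen.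

Compound 4, `OCc1ccc(/C=N/N(Cc2ccccc2)Cc2ccccc2)o1`, differs from compound 3 in one place: hydroxy in place of methyl on a saturated chain carbon bound to an aromatic carbon. Read one bond further out, ethyl becomes hydroxymethyl and 5-ethylfuran-2-yl becomes 5-(hydroxymethyl)furan-2-yl. Within the data shown here, no measured step touches this chain; every step so far replaces the whole group on the carbon with a double bond to nitrogen, and the one step that kept an oxygen-bearing group on that carbon, a 1.5-fold higher number from compound 1 to compound 3 (0.18 log units; within the scatter), stayed within the scatter. With nothing directly comparable, the expected step from compound 3 to compound 4 in this assay is none beyond the scatter, held with wide uncertainty: a 1.5-fold higher number from compound 3 to compound 4 (0.18 log units; within the scatter). Compound 4 is therefore estimated at 500 nM, within a range from 150 nM to 1800 nM.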

Compound 4, half-maximal inhibitory concentration: 16000 nM
Compound 4: the middle estimate sits 32-fold (1.51 log units) below what was measured, and the stated range ends below it.
By their numbers in this assay, from the lowest: compounds 1 and 3 (each within the scatter of the next); then compound 2; then compound 4.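

In this assay, the chain of compound 3 proved highly sensitive to a single-atom exchange, with hydroxy in place of methyl on a saturated chain carbon bound to an aromatic carbon giving a 48-fold higher number from compound 3 to compound 4 (1.69 log units; beyond the scatter) as the step. Earlier, only replacing the whole group on the carbon with a double bond to nitrogen had produced a large step, and 5-ethylfuran-2-yl had stayed within the scatter of 4-methoxyphenyl, but 5-(hydroxymethyl)furan-2-yl does not stay close, with a 73-fold higher number from compound 1 to compound 4 (1.86 log units; beyond the scatter) as its step. It also lies past pyridin-3-yl, with a 4.3-fold higher number from compound 2 to compound 4 (0.64 log units; beyond the scatter) as the step, which leaves compound 4 the weakest inhibitor of the four. Nothing measured here accounts for this loss.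

The compounds shown leave open whether the loss belongs to the free hydroxy itself, a question that methoxymethyl, aminomethyl, a carboxylic acid or a longer chain ending in hydroxy could address in the same place. They also leave open whether hydroxymethyl would cost as much on a pyridin-3-yl or phenyl group as it does on the furan-2-yl group.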